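Two Limit Values and a Third Anilino Substituent

The source may report more compounds than this note shows. Statements on the series, on what has been measured and on what is new or still open speak of the compounds shown alone.

Compound 1, `CCCCCCCCCCCCCCNc1nc(SCc2ccc(C(F)(F)F)cc2)nc2ccccc12`, gives in a functional assay on HGC-27 cells (Homo sapiens) for cytotoxicity, read by MTT assay, with a stated time of 72 h (a lower number here means a stronger inhibitor, a higher number a weaker inhibitor), a limit rather than a number: > 50000 nM.
Compound 2, `CCOc1ccccc1Nc1nc(SCc2ccc(C(F)(F)F)cc2)nc2ccccc12`, gives in this assay likewise only a limit: > 50000 nM.

Compound 2 therefore stands where every measured value stands, namely at the limit of > 50000 nM in this assay, at which 2 of the 2 values shown sit. Nothing separates it from compound 1 on the numbers shown, since both are limits of the assay and not numbers.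

Compound 3, `FC(F)(F)c1ccc(CSc2nc(Nc3ccc(C(F)(F)F)cc3)c3ccccc3n2)cc1`, has not yet been measured. It differs from compound 2 by 4-(trifluoromethyl)phenyl in place of 2-ethoxyphenyl on a nitrogen on an aromatic ring. Among the measured compounds shown here, no step between measured compounds is available to guide this change, and both recorded values sit at the same limit, so no step beyond the usual scatter in this assay is expected in either direction.

On that basis compound 3 is expected to give 50000 nM, with a range from 15000 nM to 100000 nM, and the step of a number no higher from compound 2 to compound 3 (the limit leaves the size open) is estimated to be flat, most likely reported again as a limit.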

Compound 3, half-maximal inhibitory concentration: 7560 nM
Compound 3: the middle estimate sits 6.6-fold (0.82 log units) above what was measured; measured number outside the range, below it.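

Among the compounds shown here, the anilino substituent on this nitrogen is the first change to bring a measurable value in this assay, so the place is not indifferent to what sits on it. Putting 4-(trifluoromethyl)phenyl in place of 2-ethoxyphenyl gives an at least 6.6-fold lower number from compound 2 to compound 3 (0.82 log units; beyond the scatter), a change that the two earlier compounds could not reveal, as neither gave a number: the limit of > 50000 nM in this assay, at which 2 of the 3 values shown sit. Compound 2 gives > 50000 nM, which is a limit, so the step has a lower bound but no known full size.

The compounds shown leave open whether the step belongs to the trifluoromethyl group entering or to the ethoxy group leaving. An unsubstituted phenyl, or a phenyl carrying a nitrile or a carboxylic acid, on the same nitrogen would begin to separate these two readings.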